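Adding a Hydroxy Group to Compound 2

The source may hold more compounds than are shown below. What is called first, only, known or untested is meant among the compounds shown, and "the series" means these compounds.

Compound 2 `N=C(NCc1ccccc1)[C@@H]1CCC(=O)N1Cc1ccccc1[N+](=O)[O-]` gives 28.8% in a functional assay on SH-SY5Y cells (Homo sapiens) for cytotoxicity, read by MTT assay, with stated times of 8 h, 30 min and 12 h, tested at 0.5 uM (a lower number here means a weaker effect, a higher number a stronger effect of the compound at the concentration tested), the low end of the two numbers recorded, though compound 1 `N=C(NCc1ccc(O)cc1)[C@@H]1CCC(=O)N1Cc1ccccc1`, giving 35.4%, lies within the scatter of it. Compound 3 `N=C(NCc1ccc(O)cc1)[C@@H]1CCC(=O)N1Cc1ccccc1[N+](=O)[O-]`, not yet measured, differs from compound 2 by hydroxy in place of hydrogen on an aromatic carbon. For the measured compounds named here, no measured pair isolates this change, and the two values in hand sit within the scatter of each other, so no step beyond the scatter is expected in this assay in either direction. Compound 3 is therefore estimated at 32%, between 20% and 45%. The expected step is a number 3.2 percentage points higher from compound 2 to compound 3 (within the scatter).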

Compound 3, a percentage reported as activity, at one concentration (the size of the read-out at that concentration, not a potency): 26.9%
Beside the measured number, compound 3's estimate is 5.1 percentage points above it; the range from low to high includes it.
By their numbers in this assay, from the lowest: compounds 3, 2 and 1 (each within the scatter of the next).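

In this assay, for the compounds shown here, the change from benzylamino to (4-hydroxybenzyl)amino gives a number 1.9 percentage points lower from compound 2 to compound 3 (within the scatter), the first pair to isolate hydroxy in place of hydrogen at this position. Nitro in place of hydrogen on an aromatic carbon gives a number 8.5 percentage points lower from compound 1 to compound 3 (within the scatter), so neither single change moves the read-out beyond the scatter. Nothing at hand offers an explanation for this result. As far as these compounds go, whether an amine, a carboxylic acid or a methoxy group at this position would shift the number beyond the scatter stays open. Also open, from the compounds shown here alone, is whether hydroxy behaves the same without the nitro group.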